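The source may report more compounds than this note shows. Statements on the series, on what has been measured and on what is new or still open speak of the compounds shown alone.

Measured compounds:
Compound 1 `C=C(Br)C(=O)Nc1cccc(-c2cn3nc(-c4ccc(C)cc4)sc3n2)c1` gives 920 nM in a functional assay on L1210 cells (Mus musculus) for inhibition, read by cell counting, with a stated time of 2 days; a lower number here means a stronger inhibitor, a higher number a weaker inhibitor.
Compound 2 `Nc1cccc(-c2cn3nc(-c4ccc(F)cc4)sc3n2)c1` gives >= 250000 nM in this assay, which is a limit of the assay rather than a number.
Compound 3 `Nc1cccc(-c2cn3nc(-c4ccccc4)sc3n2)c1` gives 32000 nM in this assay.

Among the two numbers shown, compound 1 stands lowest; its nearest neighbour is compound 3, with a higher number, and the remaining entry is a limit (the limit of >= 250000 nM in this assay, at which 1 of the 3 values shown sits).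

Compound 4 `C=C(Br)C(=O)Nc1cccc(-c2cn3nc(-c4ccc(OC)cc4)sc3n2)c1` differs from compound 1 in one place: methoxy in place of methyl on an aromatic carbon. Cut one bond further out, the same difference reads 4-methylphenyl to 4-methoxyphenyl.

For the measured compounds named here, the only measured step in this set, an at least 7.8-fold lower number from compound 2 to compound 3 (0.89 log units; beyond the scatter), concerns hydrogen in place of fluoro at the same position, in compounds that carry an amine where compound 1 and compound 4 carry the acrylamide. It shows that a change at this position can matter, but it is not the change from methyl to methoxy, so it gives no direction for the present step. The expected step in this assay is therefore no change beyond the scatter.

Compound 4 is estimated at 900 nM, between 300 nM and 2700 nM, meaning an expected step of a 1.0-fold lower number from compound 1 to compound 4 (0.01 log units; within the scatter).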

Compound 4, half-maximal inhibitory concentration: 940 nM
Compound 4: the middle estimate sits 1.0-fold (0.02 log units) below what was measured; low and high end bracket the measured number.
By their numbers in this assay, from the lowest: compounds 1 and 4 (each within the scatter of the next); then compound 3. At a limit, above all of these: compound 2.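

In this assay, placing methoxy instead of methyl on the aromatic carbon para to a large group gives a 1.0-fold higher number from compound 1 to compound 4 (0.01 log units; within the scatter). The earlier step at this position, between fluoro and hydrogen, showed that a change there can matter in compounds carrying an amine; this pair shows that, with the acrylamide in place, methyl and methoxy are interchangeable in this assay, even though methoxy adds an oxygen and one more heavy atom. Nothing shown here gives a reason for this close match.

Going by these compounds, whether the same holds for a carboxylic acid, an amine or a longer chain such as butoxy at this position remains open. So does whether fluoro and hydrogen would differ in compounds carrying the acrylamide as they do in those carrying the amine.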